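A few compounds are considered here, and "the series" means these few. Any claim that something is new, unique, unknown or untested is made for them only; others in the source may bear on it.

Measured compounds:
compound 1 `CC(O)(CSc1ccc(S(F)(F)(F)(F)F)cc1)C(=O)Nc1ccc(S(F)(F)(F)(F)F)cc1` — 18300 nM
compound 2 `CC(O)(CSc1ccc(F)cc1)C(=O)Nc1ccc(S(F)(F)(F)(F)F)cc1` — 12500 nM
compound 3 `CC(O)(CS(=O)(=O)c1ccc(S(F)(F)(F)(F)F)cc1)C(=O)Nc1ccc(S(F)(F)(F)(F)F)cc1` — 29200 nM

All three were tested in a functional assay on LNCaP cells (Homo sapiens) for antiproliferative activity, read by propidium iodide staining, with a stated time of 96 h; a higher number here means a weaker inhibitor, a lower number a stronger inhibitor. Compound 2 arises from compound 1 by one fluorine atom in place of a group of 6 heavy atoms (5 fluorine, 1 sulfur; no ring), on an aromatic carbon. This step gave a 1.5-fold lower number from compound 1 to compound 2 (0.17 log units; within the scatter). Compound 4 `CC(O)(CS(=O)(=O)c1ccc(F)cc1)C(=O)Nc1ccc(S(F)(F)(F)(F)F)cc1` is the unmeasured analogue that arises from compound 3 by the same change, (one fluorine atom in place of a group of 6 heavy atoms (5 fluorine, 1 sulfur; no ring), on an aromatic carbon). The difference between the core of compound 1 and the core of compound 3 is not broken down here. In this assay compound 3 stands highest of the three, though its gap to compound 1 lies within the scatter, while its gap to compound 2 lies beyond it.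

Going by the values given here, the one measured instance of this change gave a 1.5-fold lower number from compound 1 to compound 2 (0.17 log units; within the scatter), and nothing in the data points to a different response on the core of compound 3. For compound 4 a step of about that size is expected, a 1.5-fold lower number from compound 3 to compound 4 (0.16 log units; within the scatter). Compound 4 is therefore estimated at 20000 nM, with a likely range from 10000 nM to 40000 nM.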

Compound 4, half-maximal inhibitory concentration: 18200 nM
For compound 4 the middle estimate is 1.1-fold (0.04 log units) above the measured one; the range from low to high includes it.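

In this assay, exchanging the group of five fluorine atoms and one sulfur for fluoro on the core of compound 3 gives a 1.6-fold lower number from compound 3 to compound 4 (0.21 log units; within the scatter). Set beside the earlier step, the change carries from one core to the other without a detectable difference: the same change on two cores in this assay, a 1.5-fold lower number (0.17 log units; within the scatter) from compound 1 to compound 2 and a 1.6-fold lower number (0.21 log units; within the scatter) from compound 3 to compound 4, 1.1-fold (0.04 log units) apart, within the scatter of two such steps. Each step lies within the scatter, so this shows agreement between two cores only; it does not show that the change itself shifts the number, nor that other cores would respond alike.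

Still open, from the compounds shown here alone, is how a trifluoromethyl, a nitrile or an amine would read in place of the fluoro. Also open, going by these compounds, is whether the same agreement holds for a sulfoxide core.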